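Pyridin-3-yl for 4-methoxyphenyl: expected gain in solubility

The source may report more compounds than this note shows. Statements on the series, on what has been measured and on what is new or still open speak of the compounds shown alone.

Two compounds have been examined in a physicochemical assay for solubility, read by nephelometry, measured as kinetic solubility, at pH 2.0; a higher number here means a more soluble compound, a lower number a less soluble compound. Compound 1 `CCOC(=O)C1=C(O)/C(=C\c2cc(C)n(-c3ccc(F)cc3)c2C)N=C1C` gives 6.3 ug/mL. Compound 2 `CCOC(=O)C1=C(C)N/C(=C/c2cc(C)n(-c3ccc(OC)cc3)c2C)C1=O` gives 3.1 ug/mL, the lower of the two numbers, and the gap between the two compounds lies beyond the usual scatter of this assay. Among the compounds with values here, no step between compounds differing in a single place has been worked out, so the two values are all that is known here.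

Compound 3 `CCOC(=O)C1=C(C)N/C(=C/c2cc(C)n(-c3cccnc3)c2C)C1=O` has not yet been measured. It differs from compound 2 in one place: pyridin-3-yl in place of 4-methoxyphenyl on an aromatic nitrogen. With nothing else on record to set the size of this change, compound 3 is expected to come out higher than compound 2 in this assay, and the step from compound 2 to compound 3 is estimated at a 6.5-fold higher number from compound 2 to compound 3 (0.81 log units; beyond the scatter). Compound 3 is therefore expected to give about 20 ug/mL, with a range from 5 ug/mL to 80 ug/mL.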

Compound 3, solubility: > 50 ug/mL
Compound 3: only a limit was reported; the forecaster's own chance of this, stated with the estimate: 10%; middle value at least 2.5-fold (0.39 log units) away from the limit.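

Pyridin-3-yl in place of 4-methoxyphenyl, on the aromatic nitrogen whose neighbouring ring atoms each bear a methyl group, gives an at least 16-fold higher number from compound 2 to compound 3 (1.20 log units; beyond the scatter) in this assay, the first evidence that the group at this position can move the read-out by a large margin. In this assay compound 3 gives > 50 ug/mL and this is a limit of the assay, not a number. The step can therefore be read only as a minimum, with its full size hidden because compound 3 stands at the limit: the limit of > 50 ug/mL in this assay, at which 1 of the 3 values shown sits.

Whether the ring nitrogen of pyridin-3-yl accounts for the step remains open, as an unsubstituted phenyl group is not among the compounds shown. So does the question of whether pyridin-2-yl or pyridin-4-yl on the same nitrogen would give a step of similar size.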